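Saturating the Side Chain in Two Acetylphenol Isomers

This account rests on a few compounds, and the source may have more. Where it says the series, first, only, none or still open, it means among the compounds named here.

Measured so far:
- compound 1, `CCCCCCCC/C=C\CCCCCCCCOc1cc(O)c(C(C)=O)c(O)c1`, gives 31000 nM in a functional assay on HT-29 cells (Homo sapiens) for cytotoxicity, read by XTT assay, with a stated time of 72 h; on this read-out higher numbers stand for weaker inhibition and lower numbers for stronger inhibition
- compound 2, `CCCCCCCC/C=C\CCCCCCCCOc1cc(O)cc(O)c1C(C)=O`, gives 31000 nM in this assay
- compound 3, `CCCCCCCCCCCCCCCCCCOc1cc(O)c(C(C)=O)c(O)c1`, gives only a limit of the assay, > 100000 nM, in this assay

Compound 1 and compound 3 share one core and differ in a single place: decyl in place of dec-1-en-1-yl on a saturated chain carbon, eight bonds along the chain from an oxygen on an aromatic ring. This change produced an at least 3.2-fold higher number from compound 1 to compound 3 (0.50 log units; beyond the scatter). The number for compound 3 is a limit of the assay and not a measured value, as the limit of > 100000 nM in this assay, at which 1 of the 3 values shown sits, states.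

Compound 2 has the same atoms as compound 1 joined differently; the difference between the two cores is not broken down here. In this assay compound 2 stands level with compound 1 at the digits given, a gap that lies within the usual scatter.

Compound 4, `CCCCCCCCCCCCCCCCCCOc1cc(O)cc(O)c1C(C)=O`, has not yet been measured. It differs from compound 2 by decyl in place of dec-1-en-1-yl on a saturated chain carbon, eight bonds along the chain from an oxygen on an aromatic ring. Going by the values given here, this is the same change as the one between compound 1 and compound 3, made at the same place, so the earlier step is the natural guide. Because that step gave an at least 3.2-fold higher number from compound 1 to compound 3 (0.50 log units; beyond the scatter), compound 4 is expected to show a 3.9-fold higher number from compound 2 to compound 4 (0.59 log units; beyond the scatter). Resting on the value of compound 2, 31000 nM, and on that step, compound 4 is estimated at 120000 nM, with a likely range from 45000 nM to 300000 nM. An expected number this high may well come back only as a limit of the assay.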

Compound 4, half-maximal inhibitory concentration: > 100000 nM
Compound 4 was reported as a limit; the forecaster's own chance of this, stated with the estimate: 65%; the middle value is on the limit's open side.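

In this assay, putting decyl in place of dec-1-en-1-yl on the core of compound 2 gives an at least 3.2-fold higher number from compound 2 to compound 4 (0.50 log units; beyond the scatter), so the change carries over to the second core in its direction, and on both cores the shift lies beyond the scatter. Compound 4 is reported only as a limit of the assay, > 100000 nM, and not as a measured number. The two cores therefore agree on the direction of the change, but its size cannot be compared between them, and nothing shows that it transfers by the same amount: the same change on two cores in this assay, an at least 3.2-fold higher number (0.50 log units; beyond the scatter) from compound 1 to compound 3 and an at least 3.2-fold higher number (0.50 log units; beyond the scatter) from compound 2 to compound 4; the limit leaves it open whether they differ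

The compounds shown leave open how much weaker compound 3 and compound 4 really are, and so whether the two isomers still match once the chain is saturated, as compound 1 and compound 2 do with the unsaturated chain. They also leave open how either core would respond to a shorter chain, a longer chain, or a chain ending in an amine or a carboxylic acid.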